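This account rests on a few compounds, and the source may have more. Where it says the series, first, only, none or still open, it means among the compounds named here.

Compound 3 `O=C(O)c1ccc(N2CCC(NS(=O)(=O)c3cc(S(=O)(=O)c4ccccc4)ccc3C(F)(F)F)CC2)cc1` gives the lowest number of the three measured compounds in an assay on isolated protein for displacement of a labelled ligand from secreted frizzled-related protein 1 (Homo sapiens), read by fluorescence polarization, with a stated time of 30 min (on this read-out lower numbers stand for stronger inhibition and higher numbers for weaker inhibition), at 120 nM. Compound 1 `O=C(c1cccc(Cl)c1)N1CCC(NS(=O)(=O)c2cc(S(=O)(=O)c3ccccc3)ccc2C(F)(F)F)CC1` gives 300 nM, and compound 2 `O=C(c1ccc(Cl)cc1)N1CCC(NS(=O)(=O)c2cc(S(=O)(=O)c3ccccc3)ccc2C(F)(F)F)CC1` gives 300 nM. The step to compound 4 `CC(C)(O)CCN1CCC(NS(=O)(=O)c2cc(S(=O)(=O)c3ccccc3)ccc2C(F)(F)F)CC1` again alters the group on the ring nitrogen: 3-hydroxy-3-methylbutyl in place of 4-carboxyphenyl on an amine nitrogen in a ring. The measured steps that touch this place are a 2.5-fold lower number from compound 1 to compound 3 (0.40 log units; beyond the scatter) and a 2.5-fold lower number from compound 2 to compound 3 (0.40 log units; beyond the scatter), both modest, so earlier swaps at this nitrogen moved the number only a little. Going by the values given here, no measured compound carries a group without a ring here, so the direction is uncertain. Compound 4 is therefore expected to show a modest step toward a higher number, a 3.3-fold higher number from compound 3 to compound 4 (0.52 log units; beyond the scatter), with an estimate of 400 nM, between 120 nM and 1500 nM.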

Compound 4, half-maximal inhibitory concentration in the secreted frizzled-related protein 1 assay: 200 nM
Estimate against measurement, compound 4: 2.0-fold (0.30 log units) above; low and high end bracket the measured number.
By their numbers in the secreted frizzled-related protein 1 assay, from the lowest: compounds 3, 4, 1 and 2 (each within the scatter of the next, the first and the last beyond it).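

In the secreted frizzled-related protein 1 assay compound 4, which carries 3-hydroxy-3-methylbutyl on this nitrogen and has no ring in that group, gives 200 nM, and it stays within the scatter of the compounds with a ring in that group: a 1.7-fold higher number from compound 3 to compound 4 (0.22 log units; within the scatter), a 1.5-fold lower number from compound 2 to compound 4 (0.18 log units; within the scatter) and a 1.5-fold lower number from compound 1 to compound 4 (0.18 log units; within the scatter). Among these four compounds, then, a ring in this group is not required for a number in this range. In a physicochemical assay for solubility (a higher number here means a more soluble compound, a lower number a less soluble compound), compound 3 gives 25000 nM and compound 4 gives 50000 nM, and the same swap also stays within the scatter, a 2.0-fold higher number from compound 3 to compound 4 (0.30 log units; within the scatter). Nothing measured here gives a reason for these results. Still open, on these data alone, is whether a chain ending in an amine or a carboxylic acid instead of the hydroxyl would hold the number at this nitrogen.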